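A few compounds are considered here, and "the series" means these few. Any claim that something is new, unique, unknown or untested is made for them only; others in the source may bear on it.

In a functional assay on MDA-MB-231 cells (Homo sapiens) for cytotoxicity, read by sulforhodamine B assay, with a stated time of 48 h, tested at 0.01 uM (a lower number here means a stronger effect, a higher number a weaker effect of the compound at the concentration tested), three compounds have been measured:

Compound 1 `COc1cc(-c2cc(/C=C/C(=O)c3ccc(N)cc3)[nH]n2)cc(OC)c1OC` gives 109%.
Compound 2 `COc1cc(-c2cc(/C=C/C(=O)c3ccc(Cl)c(Cl)c3)[nH]n2)cc(OC)c1OC` gives 103%.
Compound 3 `COc1ccc(C(=O)/C=C/c2cc(-c3cc(OC)c(OC)c(OC)c3)n[nH]2)cc1OC` gives 104%.

Compound 3 stands second highest of the three numbers; its nearest neighbour is compound 2, with a number 1 percentage points higher from compound 2 to compound 3 (within the scatter), and the furthest is compound 1, with a number 5 percentage points lower from compound 1 to compound 3 (within the scatter). All three values lie within the scatter of one another.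

Compound 4 `COc1cc(C(=O)/C=C/c2cc(-c3cc(OC)c(OC)c(OC)c3)n[nH]2)cc(OC)c1OC` differs from compound 3 by methoxy in place of hydrogen on an aromatic carbon. For the measured compounds named here, the steps that bear on this change are those altering the ring on the carbonyl carbon, a number 1 percentage points higher from compound 2 to compound 3 (within the scatter) and a number 6 percentage points lower from compound 1 to compound 2 (within the scatter), both within the scatter. No step beyond the scatter is therefore expected in this assay, and the estimate for compound 4 is 104% (range 92% to 115%), an expected step of no change at the digits printed from compound 3 to compound 4 (within the scatter).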

Compound 4, a percentage reported as activity, at one concentration (the size of the read-out at that concentration, not a potency): 110%
For compound 4 the middle estimate is 6 percentage points below the measured one; the range from low to high includes it.
By their numbers in this assay, from the lowest: compounds 2, 3, 1 and 4 (each within the scatter of the next).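

In this assay, methoxy in place of hydrogen on an aromatic carbon, ortho to a methoxy group, gives a number 6 percentage points higher from compound 3 to compound 4 (within the scatter) and so stays within the scatter. The earlier compounds shown here showed only exchanges of the whole ring on the carbonyl carbon; this result shows that adding a group to that ring, at this position, also produces no step that can be read. No measured evidence bears on this result.

From the compounds shown here alone, it remains open whether a hydroxy group or a chlorine at this position, or an ethoxy chain in place of the methoxy, would give a step beyond the scatter in this assay or stay within it.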